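This account rests on a few compounds, and the source may have more. Where it says the series, first, only, none or still open, it means among the compounds named here.

Working notes on the series. Compound 1 `Cc1nc2cc(-c3ccccc3)nn2c(-c2cc(F)c3c(c2C)CCCO3)c1C(OC(C)(C)C)C(=O)O` gives 218 nm/s in an ADME assay for permeability, using PAMPA, with a stated time of 4 h, at pH 7.4, tested at 100 uM; on this read-out higher numbers stand for higher permeability and lower numbers for lower permeability. Compound 2 `Cc1nc2cc(-c3cccc(OCc4ccccc4)c3)nn2c(-c2cc(F)c3c(c2C)CCCO3)c1C(OC(C)(C)C)C(=O)O` gives 570 nm/s in this assay, and compound 3 `Cc1nc2cc(-c3cccc(Oc4ccccc4)c3)nn2c(-c2cc(F)c3c(c2C)CCCO3)c1C(OC(C)(C)C)C(=O)O` gives 472 nm/s in this assay. Compound 3 stands with compound 2 at the upper end of the three numbers, the two within scatter of each other, and clear of compound 1 by a 2.2-fold higher number from compound 1 to compound 3 (0.34 log units; beyond the scatter). Compound 4 `Cc1nc2cc(-c3cccc(-c4ccccc4)c3)nn2c(-c2cc(F)c3c(c2C)CCCO3)c1C(OC(C)(C)C)C(=O)O` differs from compound 3 by phenyl in place of phenoxy on an aromatic carbon. Going by the values given here, no measured step takes phenoxy to phenyl; the nearest are a 2.2-fold higher number from compound 1 to compound 3 (0.34 log units; beyond the scatter) and a 1.2-fold lower number from compound 2 to compound 3 (0.08 log units; within the scatter), the second within scatter, so no step beyond the scatter is expected in this assay. Compound 4 is estimated at 500 nm/s, between 280 nm/s and 900 nm/s, which means an expected 1.1-fold higher number from compound 3 to compound 4 (0.03 log units; within the scatter).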

Compound 4, apparent permeability: 652 nm/s
For compound 4 the middle estimate is 1.3-fold (0.12 log units) below the measured one; the measured number falls inside the stated range.
By their numbers in this assay, from the lowest: compound 1; then compounds 3, 2 and 4 (each within the scatter of the next).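

In this assay phenyl on this aromatic carbon shows a 1.4-fold higher number from compound 3 to compound 4 (0.14 log units; within the scatter) and a 1.1-fold higher number from compound 2 to compound 4 (0.06 log units; within the scatter) and so cannot be told apart from phenoxy or benzyloxy, even with no oxygen linking the ring. Against hydrogen at the same place, phenyl shows a 3.0-fold higher number from compound 1 to compound 4 (0.48 log units; beyond the scatter) and thus joins phenoxy and benzyloxy in standing clear of compound 1. Nothing measured bears on why these three groups read alike. On these data alone, whether an amine, a carboxylic acid or a longer chain in place of phenyl would stay with these three groups or fall back towards compound 1 remains open.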